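This account rests on a few compounds, and the source may have more. Where it says the series, first, only, none or still open, it means among the compounds named here.

Measured compounds:
compound 1, `Cc1cc(Nc2nc(NCc3ccc(F)cc3F)nc3ccccc23)n[nH]1`, 200 nM
compound 2, `Cc1cc(Nc2nc(NCc3ccc(F)c(F)c3)nc3ccccc23)n[nH]1`, 74 nM
compound 3, `Cc1cc(Nc2nc(NCc3cc(F)c(F)c(F)c3)nc3ccccc23)n[nH]1`, 870 nM

All three share one core and differ only in the benzyl group. In an assay for inhibition of high affinity nerve growth factor receptor (Homo sapiens), read by HTRF, with a stated time of 30 min, in the presence of a further agent that is not named here (a higher number here means a weaker inhibitor, a lower number a stronger inhibitor), compound 2 gives the lowest number; the cores of compound 2 and compound 1 differ by 2,4-difluorophenyl in place of 3,4-difluorophenyl on a saturated chain carbon bound to a nitrogen on an aromatic ring, and the step of a 2.7-fold lower number from compound 1 to compound 2 (0.43 log units; beyond the scatter) is modest. Within the data shown here, the single change fluoro in place of hydrogen on an aromatic carbon gives a large step, a 12-fold higher number from compound 2 to compound 3 (1.07 log units; beyond the scatter).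

Compound 4, `Cc1cc(Nc2nc(NCc3ccc(F)cc3F)nc3cc(F)ccc23)n[nH]1`, is not yet measured. It differs from compound 1 by fluoro in place of hydrogen on an aromatic carbon. This is the same kind of change as from compound 2 to compound 3, but not the same: there the place was ortho to a fluoro group, meta to a fluoro group and meta to a large group on a six-membered ring of carbon only; here the place is on a fused system of two rings, meta to a fused ring and para to a fused ring.

Among the measured compounds shown here, the only precedent, from compound 2 to compound 3, is a 12-fold higher number from compound 2 to compound 3 (1.07 log units; beyond the scatter) on a different ring, so it gives weak guidance. A smaller worsening is expected, a 1.5-fold higher number from compound 1 to compound 4 (0.18 log units; within the scatter). Compound 4 is estimated at 300 nM, between 80 nM and 1200 nM.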

Compound 4, half-maximal inhibitory concentration: 62 nM
Estimate against measurement, compound 4: 4.8-fold (0.68 log units) above, outside the stated range (below it).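

In this assay, fluoro in place of hydrogen on the fused system of two rings gives a 3.2-fold lower number from compound 1 to compound 4 (0.51 log units; beyond the scatter) and a stronger inhibitor. Set beside the earlier step on the benzyl ring, this change does not carry over from one core to another in this series, neither in size nor in direction: the same change on two cores in this assay, a 12-fold higher number (1.07 log units; beyond the scatter) from compound 2 to compound 3 and a 3.2-fold lower number (0.51 log units; beyond the scatter) from compound 1 to compound 4, 38-fold (1.58 log units) apart, beyond the scatter of two such steps.
The two steps differ in both the core and the place of the fluoro, so they do not show which of these sets the outcome.

Going by these compounds, it remains open whether the same fluoro on the fused system would give a like step with the 3,4-difluorophenyl group of compound 2. Also open, on these data alone, is whether chloro, methoxy or a nitrile at that place would follow fluoro.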